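A few compounds are considered here, and "the series" means these few. Any claim that something is new, unique, unknown or untested is made for them only; others in the source may bear on it.

In an ADME assay on MT2 cells (Homo sapiens) for cytotoxicity, read by XTT assay, with a stated time of 4 days (a higher number here means that more compound is tolerated, a lower number that less compound is tolerated), two compounds with a shared core have been measured so far. Compound 1 `Cc1cc(Br)cc(C)c1Oc1ccc(N)c(Nc2ccc(C#N)cc2)n1` gives 9610 nM, and compound 2 `C=CCc1cc(C)c(Oc2ccc(N)c(Nc3ccc(C#N)cc3)n2)c(C)c1` gives 14000 nM. Among the compounds with values here, these two values lie within the scatter of each other, so compound 2 stands level with its only neighbour. The next structure, compound 3 `Cc1cc(C#CC2CC2)cc(C)c1Oc1ccc(N)c(Nc2ccc(C#N)cc2)n1`, keeps the shared core but carries 2-cyclopropylethynyl in place of allyl on an aromatic carbon. Within the data shown here, only one measured step bears on this, a 1.5-fold higher number from compound 1 to compound 2 (0.16 log units; within the scatter), where allyl took the place of bromo on an aromatic carbon, and it stayed within the scatter. That single case says nothing direct about 2-cyclopropylethynyl, but it gives no reason to expect a step beyond the scatter, in either direction. The estimated step is a 1.3-fold lower number from compound 2 to compound 3 (0.10 log units; within the scatter). For compound 3 the expected value is 11000 nM, with an estimated range of 4500 nM to 27000 nM.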

Compound 3, half-maximal cytotoxic concentration: 5710 nM
Beside the measured number, compound 3's estimate is 1.9-fold (0.28 log units) above it, within the range that was stated.
By their numbers in this assay, from the lowest: compounds 3, 1 and 2 (each within the scatter of the next, the first and the last beyond it).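

In this assay, within the data shown here, this position on the aromatic ring does respond to what it carries: 2-cyclopropylethynyl in place of allyl gives a 2.5-fold lower number from compound 2 to compound 3 (0.39 log units; beyond the scatter) and is the first step in this small set to pass the scatter, though only modestly. The same group in place of bromo gives a 1.7-fold lower number from compound 1 to compound 3 (0.23 log units; within the scatter) and stays within the scatter, so compound 1 cannot be told apart from either of the other two, and only compound 2 and compound 3 stand apart. Nothing measured here offers a reason for the step from allyl to 2-cyclopropylethynyl. On these data alone, all three groups at this position lack hydrogen-bond donors and acceptors, so it remains open how an amine or a carboxylic acid there would fare. As far as these compounds go, whether a longer chain would move the number further also remains open.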